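Moving One Hydroxyl Group and Watching Enzyme Inhibition Change

This account rests on a few compounds, and the source may have more. Where it says the series, first, only, none or still open, it means among the compounds named here.

Of the compounds shown here, three built on a shared core have been tested in an assay on isolated protein for inhibition of DNA topoisomerase 1 (Homo sapiens), with a stated time of 30 min, tested at 100 uM; a lower number here means a weaker effect, a higher number a stronger effect of the compound at the concentration tested. Compound 1, `Oc1cccc(-c2cc(-c3ccsc3)cc(-c3cccc(O)c3)n2)c1`, gives 59.2%. Compound 2, `Oc1ccc(-c2cc(-c3ccsc3)cc(-c3cccc(O)c3)n2)cc1`, differs from compound 1 by 4-hydroxyphenyl in place of 3-hydroxyphenyl on an aromatic carbon. Compound 2 gives 17.1%, so that a number 42.1 percentage points lower from compound 1 to compound 2 (beyond the scatter). Compound 3, `Oc1ccc(-c2cc(-c3ccco3)cc(-c3cccc(O)c3)n2)cc1`, gives 100%, the highest of the three; here a number 82.9 percentage points higher from compound 2 to compound 3 (beyond the scatter). The difference between the core of compound 1 and the core of compound 3 is not broken down here.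

Compound 4, `Oc1ccc(-c2cc(-c3ccco3)cc(-c3ccc(O)cc3)n2)cc1`, has not yet been measured. It differs from compound 3 by 4-hydroxyphenyl in place of 3-hydroxyphenyl on an aromatic carbon. Going by the values given here, this is the same kind of change as the one from compound 1 to compound 2, though the surroundings differ: in compound 1 the place is meta to a 3-hydroxyphenyl group and meta to a thiophen-3-yl group, whereas in compound 3 it is meta to a 4-hydroxyphenyl group and meta to a furan-2-yl group.

Among the compounds with values here, the one earlier example of this change lowered the read-out sharply. If the change behaves the same way on the core of compound 3, a similar drop is expected, so that the step of a number 40 percentage points lower from compound 3 to compound 4 (beyond the scatter) is estimated, because compound 1 to compound 2 showed a number 42.1 percentage points lower from compound 1 to compound 2 (beyond the scatter). Within the data shown here, with only one precedent, and with compound 3 starting at the top of the range, the uncertainty is wide. For compound 4 in this assay the estimate is 60%, expected to fall between 30% and 95%.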

Compound 4, a percentage reported as inhibition, at one concentration (the size of the read-out at that concentration, not a potency): 100%
Compound 4: the middle estimate sits 40 percentage points below what was measured; the measured number lies above the stated range.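

In this assay, the swap of 3-hydroxyphenyl for 4-hydroxyphenyl did not repeat its earlier effect on the second core, with no change at the digits printed from compound 3 to compound 4 (within the scatter). Set side by side, the two examples of this one change clearly disagree: the same change on two cores in this assay, a number 42.1 percentage points lower (beyond the scatter) from compound 1 to compound 2 and no change at the digits printed (within the scatter) from compound 3 to compound 4, 42.1 percentage points apart, beyond the scatter of two such steps This shows that the effect of moving the hydroxyl group cannot simply be carried from one core to another in this series, but it does not show which difference between the cores decides the outcome, and since compound 3 gives 100% and compound 4 gives 100% at a single concentration, a read-out that is not a potency, the two could still differ at lower concentrations.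

On these data alone, it remains open how the swap would behave on other cores, and whether either of the two outcomes seen here is the more typical one. Also open, as far as these compounds go, is what would happen if a hydroxyl group gave way to an amine or a carboxylic acid, or if the thiophen-3-yl or furan-2-yl group gave way to a longer chain.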